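The source may hold more compounds than are shown below. What is called first, only, known or untested is meant among the compounds shown, and "the series" means these compounds.

Compound 2 `NC[C@@H]1CCCc2cc(S(=O)(=O)c3cccc(F)c3)ccc21` gives 0.0794 nM in an assay on isolated protein for displacement of a labelled ligand from 5-hydroxytryptamine receptor 6 (Homo sapiens); a lower number here means a stronger inhibitor, a higher number a weaker inhibitor. Among the three compounds measured so far it gives the lowest number: compound 1 `NC[C@@H]1CCCc2cc(S(=O)(=O)c3cccc(O)c3)ccc21` gives 0.251 nM, and compound 3 `CS(=O)(=O)c1cccc(S(=O)(=O)c2ccc3c(c2)CCC[C@H]3CN)c1` gives 3.98 nM. The step of a 3.2-fold lower number from compound 1 to compound 2 (0.50 log units; beyond the scatter) is modest, whereas a 16-fold higher number from compound 1 to compound 3 (1.20 log units; beyond the scatter) and a 50-fold higher number from compound 2 to compound 3 (1.70 log units; beyond the scatter) are both large, so compound 2 stands apart from compound 3 and, less sharply, from compound 1.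

Compound 4 `O=S(=O)(c1cccc(F)c1)c1ccc2c(c1)CCC[C@H]2CNCCO` has not yet been measured. It differs from compound 2 in one place: 2-hydroxyethyl in place of hydrogen on an amine nitrogen

Going by the values given here, none of the measured steps touches this part of the molecule. All three compare groups on an aromatic carbon of the distant ring; the amine nitrogen carries a hydrogen in every measured compound. Among the compounds with values here, there is therefore no measured step that bears directly on the change from compound 2 to compound 4, and the expectation must rest on the fact that compound 2 already gives the lowest number in this assay and on the small size of the entering group.

On that basis, the step from compound 2 to compound 4 is expected to be a 2.5-fold higher number from compound 2 to compound 4 (0.40 log units; beyond the scatter), which may lie within the scatter. Compound 4 is estimated to give 0.2 nM in this assay, in a range from 0.05 nM to 0.8 nM.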

Compound 4, inhibition constant: 0.126 nM
Compound 4: the middle estimate sits 1.6-fold (0.20 log units) above what was measured, within the range that was stated.
By their numbers in this assay, from the lowest: compounds 2, 4 and 1 (each within the scatter of the next, the first and the last beyond it); then compound 3.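

In this assay, the amine nitrogen carries hydrogen in all three earlier compounds, and compound 4 is the first shown with a substituent there, giving a 1.6-fold higher number from compound 2 to compound 4 (0.20 log units; within the scatter) for 2-hydroxyethyl in place of hydrogen. At this position, on an amine nitrogen whose other neighbour is a saturated chain carbon, this change therefore leaves the number indistinguishable from that of compound 2, while each earlier step, all of them on an aromatic carbon, lay beyond the scatter. No measurement is available here that would explain this outcome.

Going by these compounds, whether the same holds for other groups on this nitrogen stays open, for instance methyl, a longer chain such as 3-hydroxypropyl, or an acetyl group that would turn the amine into an amide. On these data alone, it is also open whether 2-hydroxyethyl gives a similar result with hydroxy or methylsulfonyl on the aromatic carbon, as it appears here only in a compound carrying fluoro.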